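The source may report more compounds than this note shows. Statements on the series, on what has been measured and on what is new or still open speak of the compounds shown alone.

Compound 1 `O=C(O)c1cc(-c2cscn2)ccc1O`: 95 mg/kg
Compound 2 `O=C(O)c1cc(C2N=NN=N2)ccc1O`: 110 mg/kg
Compound 3 `O=C(O)c1cc(-c2ncco2)ccc1O`: 100 mg/kg

All three were tested in a functional assay on the whole organism for inhibition, with Rattus norvegicus as the target, read by paw edema; a lower number here means that less compound is needed, a higher number that more compound is needed for the effect. Compound 1 holds the lowest of the three numbers, yet its gap to compound 3, a 1.1-fold higher number from compound 1 to compound 3 (0.02 log units; within the scatter), and its gap to compound 2, a 1.2-fold higher number from compound 1 to compound 2 (0.06 log units; within the scatter), both lie within the scatter, so the three cannot be told apart. Compound 4 `O=C(O)c1cc(-c2ccns2)ccc1O` differs from compound 1 in one place: 1,2-thiazol-5-yl in place of 1,3-thiazol-4-yl on an aromatic carbon. The two measured steps just named each swapped one ring for another on the same carbon and neither moved the number beyond the scatter, and the change to compound 4 is smaller still. In this assay the step to compound 4 is therefore expected to be none beyond the scatter, a 1.1-fold higher number from compound 1 to compound 4 (0.02 log units; within the scatter). Compound 4 is estimated at 100 mg/kg, with a range from 60 mg/kg to 170 mg/kg.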

Compound 4, dose for half-maximal effect in the Rattus norvegicus assay: 80 mg/kg
Compound 4: middle estimate off by 1.3-fold (0.10 log units), on the high side; the measured number falls inside the stated range.
By their numbers in the Rattus norvegicus assay, from the lowest: compounds 4, 1, 3 and 2 (each within the scatter of the next).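

In the Rattus norvegicus assay the swap of one ring for another still changes little: a 1.2-fold lower number from compound 1 to compound 4 (0.07 log units; within the scatter), a 1.3-fold lower number from compound 3 to compound 4 (0.10 log units; within the scatter) and a 1.4-fold lower number from compound 2 to compound 4 (0.14 log units; within the scatter). In a physicochemical assay for solubility, in phosphate buffer, at pH 7 (a lower number here means a less soluble compound, a higher number a more soluble compound), however, compound 1 gives 2700 ug/mL and compound 4 gives 7300 ug/mL. On this carbon, joining the same ring atoms differently therefore leaves the Rattus norvegicus assay within the scatter yet moves the physicochemical assay beyond it: the measured solubility of compound 1, 2700 ug/mL, and of compound 4, 7300 ug/mL, a 2.7-fold higher number (0.43 log units; beyond the scatter)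

As far as these compounds go, whether the rings of compound 2 and compound 3 would behave in the same way in the physicochemical assay remains open. So does the effect of an amine or a longer chain on this carbon in place of a ring.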